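A few compounds are considered here, and "the series" means these few. Any claim that something is new, unique, unknown or untested is made for them only; others in the source may bear on it.

In a functional assay on HeLa cells (Homo sapiens) for cytotoxicity, read by MTT assay (on this read-out higher numbers stand for weaker inhibition and lower numbers for stronger inhibition), the three measured compounds gave these results:
Compound 1, `CCCCC(O)CC(=O)O[C@H](CC=C(C)C)C1=CC(=O)c2c(O)ccc(O)c2C1=O`: 72200 nM.
Compound 2, `CC(C)=CC[C@@H](OC(=O)c1ccoc1)C1=CC(=O)c2c(O)ccc(O)c2C1=O`: > 100000 nM, a limit of the assay and not a number.
Compound 3, `CCC(C)(O)CC(=O)O[C@H](CC=C(C)C)C1=CC(=O)c2c(O)ccc(O)c2C1=O`: 25200 nM.

Compound 3 gives the lowest of the two numbers; its nearest neighbour is compound 1, with a 2.9-fold lower number from compound 1 to compound 3 (0.46 log units; beyond the scatter). Compound 2 sits at the limit of > 100000 nM in this assay, at which 1 of the 3 values shown sits, so from it only bounds can be drawn: an at least 1.3-fold higher number from compound 1 to compound 2 (0.14 log units; that floor lies within the scatter) and an at least 3.9-fold lower number from compound 2 to compound 3 (0.59 log units; beyond the scatter).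

Compound 4, `CC(C)=CC[C@@H](OC[C@@H](C)O)C1=CC(=O)c2c(O)ccc(O)c2C1=O`, differs from compound 3 by 2-hydroxypropyl in place of (2-hydroxy-2-methylbutyl)carbonyl on an oxygen on a saturated carbon. All three measured steps vary the group attached to the carbonyl carbon while keeping the ester in place; none removes the carbonyl or puts a 2-hydroxypropyl on that oxygen. The measured steps therefore only show how far the numbers in this assay have moved so far, from compound 3 up to the limit of compound 2, and bear on the step to compound 4 only loosely. With the shared core kept and a hydroxyl-bearing side chain retained, a change of modest size, within or a little beyond the scatter, is expected, and its direction cannot be told from these data. Compound 4 is therefore estimated at 50000 nM, with a range from 15000 nM to 150000 nM, which corresponds to an expected step of a 2.0-fold higher number from compound 3 to compound 4 (0.30 log units; within the scatter).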

Compound 4, half-maximal inhibitory concentration: 22500 nM
Estimate against measurement, compound 4: 2.2-fold (0.35 log units) above; the range from low to high includes it.
By their numbers in this assay, from the lowest: compounds 4 and 3 (each within the scatter of the next); then compound 1. At a limit, above all of these: compound 2.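

In this assay, among the compounds shown here, the step from (2-hydroxy-2-methylbutyl)carbonyl to 2-hydroxypropyl on this oxygen on a saturated carbon takes away the carbonyl, which no earlier step had done, and it reads as a 1.1-fold lower number from compound 3 to compound 4 (0.05 log units; within the scatter). Among these compounds, then, the carbonyl on this oxygen is not required for a number of this size, since the values of compound 3 and compound 4 cannot be told apart; the smaller group, with 4 heavy atoms in place of 8, also fits here. Compound 4 stands apart from the other two much as compound 3 does, with a 3.2-fold lower number from compound 1 to compound 4 (0.51 log units; beyond the scatter) and, as a bound only, an at least 4.4-fold lower number from compound 2 to compound 4 (0.64 log units; beyond the scatter), the value of compound 2 being a limit of the assay and not a number: the limit of > 100000 nM in this assay, at which 1 of the 4 values shown sits.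

What the compounds shown leave open is which part of the 2-hydroxypropyl group matters, since a plain propyl chain, the opposite configuration at its defined stereocentre or a methyl ether of its hydroxyl does not appear among them. Going by these compounds, it also remains open how this oxygen would tolerate an amine, a carboxylic acid or a longer chain bearing a hydroxyl, and whether any such group would move the number beyond the scatter in either direction.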